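Swapping the dimethoxyphenyl on the sulfur for naphthalene

A few compounds are considered here, and "the series" means these few. Any claim that something is new, unique, unknown or untested is made for them only; others in the source may bear on it.

Compound 1, `COc1ccc(SCc2ccc(/C=C/C(=O)Nc3ccccc3N)cc2)cc1OC`: 21.9%
Compound 2, `Nc1ccccc1NC(=O)c1ccc(CSc2nccc(C(F)(F)F)n2)cc1`: 83.4%
Compound 3, `COc1ccc(SCc2ccc(C(=O)Nc3ccccc3N)cc2)cc1`: 79.7%

All three were tested in a functional assay on HeLa cells (Homo sapiens) for inhibition, read by CCK-8 assay, with a stated time of 72 h, tested at 8 uM; on this read-out higher numbers stand for more inhibition of growth at the one concentration tested and lower numbers for less inhibition of growth. On that read-out compound 1 stands lowest of the three. Compound 3 comes closest to it, yet its value lies far above that of compound 1, well beyond the usual scatter; compound 2 lies further above still, also beyond the scatter. Going by the values given here, both of those compounds differ from compound 1 in more than one place, so none of the measured pairs isolates a single change.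

Compound 4, `Nc1ccccc1NC(=O)/C=C/c1ccc(CSc2cccc3ccccc23)cc1`, has not yet been measured. Relative to compound 1 its structure differs as follows: naphthalen-1-yl in place of 3,4-dimethoxyphenyl on a sulfur. Among the compounds with values here, no measured pair shows what this exchange on the sulfur does, so the expectation rests on the low starting point of compound 1 alone and carries wide uncertainty. In this assay compound 4 is expected to give 35%, with a likely range from 10% to 70%. The step from compound 1 to compound 4 is estimated at a number 13.1 percentage points higher from compound 1 to compound 4 (beyond the scatter), a modest rise that may not clear the scatter.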

Compound 4, percent growth inhibition at one concentration: 22.1%
For compound 4 the middle estimate is 12.9 percentage points above the measured one; measured number inside the range.
By their numbers in this assay, from the lowest: compounds 1 and 4 (each within the scatter of the next); then compounds 3 and 2 (each within the scatter of the next).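

In this assay, going by these compounds alone, placing naphthalen-1-yl in place of 3,4-dimethoxyphenyl on a sulfur gives a step of a number 0.2 percentage points higher from compound 1 to compound 4 (within the scatter), the first single exchange that can be read at this position. The exchange replaces one six-membered aromatic ring carrying 2 hydrogen-bond acceptors with 2 such rings carrying 0 hydrogen-bond acceptors, yet at the same count of 10 heavy atoms it does not separate the two compounds on this read-out. No supporting measurement bears on the reason for this result.

Going by these compounds, whether a group of a different kind on the sulfur, such as a carboxylic acid or an amine on a short carbon chain, would change the number remains open. Also open, on these data alone, is whether this exchange would stay as silent on a different core.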